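Anilide variation at the cyclopropane diamide terminus

A few compounds are considered here, and "the series" means these few. Any claim that something is new, unique, unknown or untested is made for them only; others in the source may bear on it.

Among the compounds with values here, compound 2 `CN(C)C(=O)c1cc2cnc(Nc3ccc(NC(=O)C4(C(=O)Nc5cccc(C(F)(F)F)c5)CC4)cc3)nc2n1C1CCCC1` gives 15.7% in a functional assay on A549 cells (Homo sapiens) for inhibition, read by CCK-8 assay, with a stated time of 72 h, tested at 1 uM (on this read-out higher numbers stand for more inhibition of growth at the one concentration tested and lower numbers for less inhibition of growth), the higher of the two numbers known so far; compound 1 `CN(C)C(=O)c1cc2cnc(Nc3ccc(NC(=O)C4(C(=O)Nc5ccc(Br)cc5)CC4)cc3)nc2n1C1CCCC1` gives -6.6% in this assay. Within the data shown here, the one measured step, a number 22.3 percentage points higher from compound 1 to compound 2 (beyond the scatter), separates them. Compound 3 `CN(C)C(=O)c1cc2cnc(Nc3ccc(NC(=O)C4(C(=O)Nc5ccc(O)cc5)CC4)cc3)nc2n1C1CCCC1` carries 4-hydroxyphenyl in place of 3-(trifluoromethyl)phenyl on an amide-type nitrogen. The known step sits on the same amide-type nitrogen, but it exchanges two groups neither of which is the one entering here, so it shows only that this position can move the read-out modestly and gives no direction for the present change. A step in this assay from compound 2 to compound 3 of about the size of the known one, in either direction, remains plausible. The step is tentatively expected to be a number 12.7 percentage points lower from compound 2 to compound 3 (beyond the scatter). Compound 3 is therefore expected to give 3% in this assay, with a range from -15% to 22%.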

Compound 3, percent growth inhibition at one concentration: 93.6%
The estimate for compound 3 lay 90.6 percentage points below the measured number, outside the stated range (above it).
By their numbers in this assay, from the lowest: compound 1; then compound 2; then compound 3.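

4-Hydroxyphenyl in place of 3-(trifluoromethyl)phenyl on the amide-type nitrogen gives a number 77.9 percentage points higher from compound 2 to compound 3 (beyond the scatter) in this assay and shows that this position can do far more than the modest a number 22.3 percentage points higher from compound 1 to compound 2 (beyond the scatter) suggested. Hydroxy in place of bromo on an aromatic carbon gives a number 100.2 percentage points higher from compound 1 to compound 3 (beyond the scatter) and makes compound 3 the most active of the three, so one substituent on this ring can separate a compound with no growth inhibition from one with near-complete inhibition at the concentration tested. No measurement shown here bears on the origin of this jump.

From the compounds shown here alone, it remains open whether the gain is specific to the hydroxy group, or whether a methoxy group or an amine in its place would keep it. Going by these compounds, with one concentration per compound, the concentration dependence of compound 3 also remains open.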